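Sulfonyl for sulfanyl on the bromo analogue

A few compounds are considered here, and "the series" means these few. Any claim that something is new, unique, unknown or untested is made for them only; others in the source may bear on it.

Measured so far in a functional assay on DU-145 cells (Homo sapiens) for inhibition, read by trypan blue exclusion, with a stated time of 96 h; on this read-out higher numbers stand for weaker inhibition of growth and lower numbers for stronger inhibition of growth:
compound 1, `CCOc1ccc(/C=C(\C(=O)c2ccc(Cl)cc2)S(=O)(=O)c2ccc(C)cc2)cc1OC`, gives 1000 nM;
compound 2, `CCOc1ccc(/C=C(/SCc2ccc(F)cc2)C(=O)c2ccc(Br)cc2)cc1OC`, gives 50000 nM;
compound 3, `CCOc1ccc(/C=C(/SCc2ccc(F)cc2)C(=O)c2ccc(Cl)cc2)cc1OC`, gives 1000 nM.

Compound 2 stands highest of the three numbers in this assay, with both compound 1 and compound 3 far below it. Compound 4, `CCOc1ccc(/C=C(\C(=O)c2ccc(Br)cc2)S(=O)(=O)c2ccc(C)cc2)cc1OC`, has not been measured; it differs from compound 2 by (4-methylphenyl)sulfonyl in place of (4-fluorobenzyl)sulfanyl on a double-bonded chain carbon bound to a carbonyl carbon and a double-bonded chain carbon. Among the measured compounds shown here, the one measured step that bears on this change is the reverse exchange, no change at the digits printed from compound 1 to compound 3 (within the scatter). The other step, a 50-fold lower number from compound 2 to compound 3 (1.70 log units; beyond the scatter), concerns the halogen and not the group exchanged here. Compound 4 is therefore expected to show no step beyond the scatter, no change at the digits printed from compound 2 to compound 4 (within the scatter). Compound 4 is estimated at 50000 nM, within 10000 nM to 150000 nM.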

Compound 4, concentration for 50% growth inhibition: 1000 nM
Estimate against measurement, compound 4: 50-fold (1.70 log units) above; measured number below the stated range.
By their numbers in this assay, from the lowest: compounds 1, 3 and 4 (each within the scatter of the next); then compound 2.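

In this assay, the exchange on the bromo core gives a 50-fold lower number from compound 2 to compound 4 (1.70 log units; beyond the scatter), so the effect of this change at the double-bonded chain carbon depends on the halogen and does not carry over from the chloro pair: the same change on two cores in this assay, no change at the digits printed (within the scatter) from compound 1 to compound 3 and a 50-fold higher number (1.70 log units; beyond the scatter) from compound 4 to compound 2, 50-fold (1.70 log units) apart, beyond the scatter of two such steps

With (4-methylphenyl)sulfonyl in place, the halogen exchange gives no change at the digits printed from compound 1 to compound 4 (within the scatter), so the large halogen step appears only with (4-fluorobenzyl)sulfanyl: the same change on two cores in this assay, a 50-fold lower number (1.70 log units; beyond the scatter) from compound 2 to compound 3 and no change at the digits printed (within the scatter) from compound 4 to compound 1, 50-fold (1.70 log units) apart, beyond the scatter of two such steps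

Going by these compounds, whether compound 2 is a lone exception remains open. An iodo group on the aromatic carbon, or an amine on the chain carbon, could help settle that.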